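The compounds below may be only part of what the source reports. "The series", "measured", "known", "first", "only" and "open" are said of these compounds alone.

Working notes on the series. Compound 1 `O=C(NCc1cc(Cl)ccc1-n1cnnn1)[C@@H]1C[C@@H]2C[C@@H]2N1C(=O)[C@H](O)c1ccccc1F` gives 16 10^-6 cm/s in an ADME assay on Caco-2 cells (Homo sapiens) for permeability, read by LC-MS, in the apical to basolateral direction, with a stated time of 60 min, at pH 6.5; a lower number here means that the compound crosses the layer more slowly, a higher number that the compound crosses the layer faster. Compound 3 `CCCC[C@@H](O)C(=O)N1C[C@H]2C[C@H]2[C@H]1C(=O)NCc1cc(Cl)ccc1-n1cnnn1` gives 33 10^-6 cm/s in this assay, and compound 2 `O=C(NCc1cc(Cl)ccc1-n1cnnn1)[C@@H]1CCNN1C(=O)[C@H](O)c1ccccc1` gives 5.3 10^-6 cm/s. Compound 1 thus stands second highest of the three numbers, closer to compound 3 than to compound 2, with both gaps lying beyond the scatter. The next compound, compound 4 `O=C(NCc1cc(Cl)ccc1-n1cnnn1)[C@@H]1C[C@@H]2C[C@@H]2N1C(=O)[C@H](O)Cn1cccn1`, differs from compound 1 in one place: (1H-pyrazol-1-yl)methyl in place of 2-fluorophenyl on a saturated chain carbon bound to a carbonyl carbon and an oxygen on a saturated carbon. Among the compounds with values here, no step between two measured compounds matches this change, so the size of the step of a 2.7-fold lower number from compound 1 to compound 4 (0.43 log units; beyond the scatter) rests on estimate alone and is expected to run downward, beyond the scatter. Compound 4 is expected to give 6 10^-6 cm/s in this assay, within a range of 3 10^-6 cm/s to 14 10^-6 cm/s.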

Compound 4, apparent permeability: 0.45 10^-6 cm/s
Compound 4: middle estimate off by 13-fold (1.12 log units), on the high side; measured number below the stated range.
By their numbers in this assay, from the lowest: compound 4; then compound 2; then compound 1; then compound 3.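

In this assay the saturated chain carbon bound to a carbonyl carbon and an oxygen proves a sensitive place, with (1H-pyrazol-1-yl)methyl in place of 2-fluorophenyl giving a 36-fold lower number from compound 1 to compound 4 (1.55 log units; beyond the scatter). Neither group carries a net charge, while the entering group counts 2 hydrogen-bond acceptors against 0 for the leaving one. No measurement shown here accounts for the size of this step. Still open, going by these compounds, is whether the step follows the change of ring or the added methyl link; a benzyl group at this place would separate the two.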